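This account rests on a few compounds, and the source may have more. Where it says the series, first, only, none or still open, it means among the compounds named here.

Working notes on the series built on the shared core of compound 1 `CN(CCNCc1cn(-c2cccc(Cl)c2)nn1)CCNc1ccnc2cc(Cl)ccc12`. In a functional assay on HCC827 cells (Homo sapiens) for antiproliferative activity, read by sulforhodamine B assay, with a stated time of 72 h (a lower number here means a stronger inhibitor, a higher number a weaker inhibitor), compound 1 gives 9400 nM, the lowest of the two numbers recorded so far. Compound 2 `CN(CCNCc1cn(CCCO)nn1)CCNc1ccnc2cc(Cl)ccc12` carries 3-hydroxypropyl in place of 3-chlorophenyl on an aromatic nitrogen; for compound 2 the result is a limit of the assay, > 200000 nM (the limit of > 200000 nM in this assay, at which 1 of the 3 values shown sits). Compound 3 `CN(CCNCc1cn(Cc2nc3ccccc3[nH]2)nn1)CCNc1ccnc2cc(Cl)ccc12` carries (1H-benzimidazol-2-yl)methyl on the same aromatic nitrogen and gives 164000 nM. Both departures from 3-chlorophenyl cost potency: an at least 21-fold higher number from compound 1 to compound 2 (1.32 log units; beyond the scatter) and a 17-fold higher number from compound 1 to compound 3 (1.24 log units; beyond the scatter). The remaining comparison is an at least 1.2-fold lower number from compound 2 to compound 3 (0.08 log units; that floor lies within the scatter).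

Compound 4 `CN(CCNCc1cn(CCC(=O)Nc2ccccn2)nn1)CCNc1ccnc2cc(Cl)ccc12` makes a third exchange on the same aromatic nitrogen: 2-((pyridin-2-yl)carbamoyl)ethyl in place of 3-chlorophenyl on an aromatic nitrogen. The two measured exchanges at this nitrogen bear directly on it, and both were large losses, so a large step upward in this assay is expected for compound 4, an 11-fold higher number from compound 1 to compound 4 (1.03 log units; beyond the scatter). Compound 4 is therefore estimated at 100000 nM, between 30000 nM and 250000 nM, with a real chance that only a limit is returned.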

Compound 4, half-maximal inhibitory concentration: > 200000 nM
Compound 4 ended at the assay's limit; the forecaster's own chance of this, stated with the estimate: 35%; middle value at least 2.0-fold (0.30 log units) from the limit.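

At this aromatic nitrogen a third replacement of 3-chlorophenyl also gives a large loss, an at least 21-fold higher number from compound 1 to compound 4 (1.32 log units; beyond the scatter), and this step rests on a limit of the assay. Compounds 3 and 4 both keep an aromatic ring further along the substituent, with a saturated chain carbon on the nitrogen, yet neither approaches compound 1, so a ring somewhere in the group is not enough in these examples; the step between them, an at least 1.2-fold higher number from compound 3 to compound 4 (0.08 log units; that floor lies within the scatter), does not separate them. The step between compound 2 and compound 4 cannot be read: the limit of > 200000 nM in this assay, at which 2 of the 4 values shown sit.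

Still open, on these data alone, is whether the activity of compound 1 depends on the ring standing directly on the aromatic nitrogen or on its chlorine. A plain phenyl and a 3-chlorobenzyl group would separate these two readings.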